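A few compounds are considered here, and "the series" means these few. Any claim that something is new, unique, unknown or untested is made for them only; others in the source may bear on it.

The measured compounds:
compound 1 `COC(=O)c1ccc(OCCCCOc2ccc(C(=O)CC3CCCC3)c(C)c2C)cc1`, 24.2%
compound 2 `Cc1c(OCCCCOc2ccc(C(=O)O)cc2)ccc(C(=O)CC2CCCC2)c1C`, 12.2%
compound 3 `Cc1c(OCCCCOc2ccc(C(=O)O)cc2)ccc(C(=O)CC(C)C)c1O`, 51.9%

All three were tested in an assay on HEK293 cells for positive allosteric modulation of metabotropic glutamate receptor 3 (Rattus norvegicus), read by thallium flux, with a stated time of 2.5 min; on this read-out lower numbers stand for smaller maximal responses and higher numbers for larger maximal responses. Compound 2 and compound 1 share one core and differ in a single place: methyl in place of hydrogen on an oxygen next to a carbonyl group. That change brought a number 12 percentage points higher from compound 2 to compound 1 (beyond the scatter). Compound 3 is built on a different core, and the difference between the two cores is not broken down here. Its maximal response is the highest of the three, beyond the scatter above both compound 1 and compound 2.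

Compound 4 `COC(=O)c1ccc(OCCCCOc2ccc(C(=O)CC(C)C)c(O)c2C)cc1` has not been measured. It arises from compound 3 by the same change, (methyl in place of hydrogen on an oxygen next to a carbonyl group), and the surroundings of the place are the same in both pairs. If the change acts as before, the step in this assay from compound 3 to compound 4 should be modest, because a number 12 percentage points higher from compound 2 to compound 1 (beyond the scatter) is the only guide available; it rests on one pair on another core, so the range is wide. The expected step is a number 10.1 percentage points higher from compound 3 to compound 4 (beyond the scatter). Compound 4 is estimated at 62%, between 45% and 80%.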

Compound 4, largest response reached (reported as percent of maximum), in percent of the reference or control that the assay uses: 22.7%
Compound 4: middle estimate off by 39.3 percentage points, on the high side; the measured number lies below the stated range.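

In this assay, the change from carboxy to methoxycarbonyl gave a number 29.2 percentage points lower from compound 3 to compound 4 (beyond the scatter). Set beside the earlier pair, the same change did not carry over from one core to the other, and even the direction of the step reversed: the same change on two cores in this assay, a number 12 percentage points higher (beyond the scatter) from compound 2 to compound 1 and a number 29.2 percentage points lower (beyond the scatter) from compound 3 to compound 4, 41.2 percentage points apart, beyond the scatter of two such steps This shows that, in this series, a step measured on one core is a poor guide to the step on another, but with only two pairs it does not show which feature of the cores makes the difference, or how the change would behave on a third core.

The compounds shown leave open whether an ethyl ester or an amide in place of the carboxy group would also give steps that differ from core to core. From the compounds shown here alone, it also remains open how a shorter or longer linking chain would alter the maximal response on either core.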